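The source may report more compounds than this note shows. Statements on the series, on what has been measured and on what is new or still open speak of the compounds shown alone.

Three compounds share one core and differ in the group that sits on an amine nitrogen in a ring. Compound 1 `CCC1(C)CC(=O)N(CC(=O)N2CCN(c3ccccc3Cl)CC2)C1=O` carries a 2-chlorophenyl there, compound 2 `Cc1cccc(N2CCN(C(=O)CN3C(=O)CC(C)C3=O)CC2)c1` a 3-methylphenyl and compound 3 `CC1CC(=O)N(CC(=O)N2CCN(c3ccc(Cl)c(Cl)c3)CC2)C1=O` a 3,4-dichlorophenyl. In a functional assay on the whole organism (strain CD1) with Mus musculus as the target, in the maximal electroshock model, with a stated time of 0.5 h (a lower number here means that less compound is needed, a higher number that more compound is needed for the effect), compound 1 gives 100 mg/kg, compound 2 gives 300 mg/kg and compound 3 gives 300 mg/kg. Compound 3 thus stands level with compound 2, and the two together hold the highest number of the three; compound 1 sits a clear distance below them, while the step of no change at the digits printed from compound 2 to compound 3 (within the scatter) shows that swapping one aryl group for another can leave the number where it was.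

The next compound, compound 4 `CC1CC(=O)N(CC(=O)N2CCN(c3ccccc3Cl)CC2)C1=O`, keeps the core of compound 3 and changes only the aryl group: 2-chlorophenyl in place of 3,4-dichlorophenyl on an amine nitrogen in a ring. Among the measured compounds shown here, no measured step covers this exact exchange. For the measured compounds named here, the one aryl swap that was measured, from compound 2 to compound 3, stayed within the scatter. Going by the values given here, compound 1, the only compound carrying a 2-chlorophenyl, also carries an extra ethyl on its core, so its lower value cannot be assigned to the aryl group alone. Balancing these, a modest lowering is expected for the step of a 1.5-fold lower number from compound 3 to compound 4 (0.18 log units; within the scatter). Compound 4 is therefore estimated to give 200 mg/kg, within a range from 90 mg/kg to 350 mg/kg.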

Compound 4, minimum effective dose: 300 mg/kg
Compound 4: middle estimate off by 1.5-fold (0.18 log units), on the low side; low and high end bracket the measured number.
By their numbers in this assay, from the lowest: compound 1; then compounds 2, 3 and 4 (each within the scatter of the next).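

With the core held fixed, the aryl group on the amine nitrogen in a ring now has three members to compare in this assay: the exchange of 3,4-dichlorophenyl for 2-chlorophenyl gives no change at the digits printed from compound 3 to compound 4 (within the scatter) and the exchange of 3-methylphenyl for 2-chlorophenyl gives no change at the digits printed from compound 2 to compound 4 (within the scatter), so these three aryl groups cannot be told apart at this position. The change at the saturated ring carbon can now be read on its own, since compounds 1 and 4 share the 2-chlorophenyl, and hydrogen in place of ethyl there gives a 3.0-fold higher number from compound 1 to compound 4 (0.48 log units; beyond the scatter), which places this difference on the core and not on the aryl group. Nothing measured here bears on why the numbers fall as they do.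

From the compounds shown here alone, whether the ethyl group has the same effect alongside 3-methylphenyl or 3,4-dichlorophenyl remains open. So does what a longer chain such as propyl on that ring carbon, or a methoxy group on the phenyl ring, would do to the dose needed.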